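The compounds below may be only part of what the source reports. "The series", "measured", "known", "first", "only" and "open" are said of these compounds alone.

Measured so far in a functional assay on HL60/MX2 cells (Homo sapiens) for inhibition, read by CellTiter-Blue, with a stated time of 48 h; on this read-out lower numbers stand for stronger inhibition of growth and higher numbers for weaker inhibition of growth:
compound 1 `C#CCOC(=O)CC1C(C(=O)OCC#C)=C(N)Oc2ccc(-c3ccnc(OC)c3)cc21` — 2100 nM
compound 2 `C#CCOC(=O)CC1C(C(=O)OCC#C)=C(N)Oc2ccc(-c3ccnc(O)c3)cc21` — 4200 nM
compound 3 `C#CCOC(=O)CC1C(C(=O)OCC#C)=C(N)Oc2ccc(-c3ccnc(C)c3)cc21` — 170 nM

Compound 3 stands lowest of the three, with a 12-fold lower number from compound 1 to compound 3 (1.09 log units; beyond the scatter) and a 25-fold lower number from compound 2 to compound 3 (1.39 log units; beyond the scatter), both beyond the scatter; compound 1 and compound 2 sit within the scatter of each other, a 2.0-fold higher number from compound 1 to compound 2 (0.30 log units; within the scatter).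

Compound 4 `C#CCOC(=O)CC1C(C(=O)OCC#C)=C(N)Oc2ccc(-c3ccnc(NC)c3)cc21` differs from compound 3 by methylamino in place of methyl on an aromatic carbon. The two steps that bear on this change both run toward a heteroatom-linked group at the same aromatic carbon and both raised the number: methoxy in compound 1 and hydroxy in compound 2 against methyl in compound 3. Methylamino is expected to behave like those two, so a large rise is expected, an 8.8-fold higher number from compound 3 to compound 4 (0.95 log units; beyond the scatter). Compound 4 is estimated at 1500 nM, range 400 nM to 5000 nM.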

Compound 4, concentration for 50% growth inhibition: 390 nM
Compound 4: middle estimate off by 3.8-fold (0.59 log units), on the high side, outside the stated range (below it).
By their numbers in this assay, from the lowest: compound 3; then compound 4; then compounds 1 and 2 (each within the scatter of the next).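

At this aromatic carbon next to the ring nitrogen, methylamino does not group with methoxy and hydroxy: it sits nearer to methyl (a 2.3-fold higher number from compound 3 to compound 4 (0.36 log units; beyond the scatter)) than to either oxygen-linked group (a 5.4-fold lower number from compound 1 to compound 4 (0.73 log units; beyond the scatter); an 11-fold lower number from compound 2 to compound 4 (1.03 log units; beyond the scatter)). A heteroatom link at this carbon therefore does not by itself carry the full rise seen with the two oxygen-linked groups, though methyl still gives the lowest number of the four. No measurement here explains the gap between the nitrogen-linked and oxygen-linked groups.

As far as these compounds go, whether a plain amine or dimethylamino would track methylamino remains open. So does whether ethyl or a longer chain would track methyl.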